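A few compounds are considered here, and "the series" means these few. Any claim that something is new, unique, unknown or untested is made for them only; others in the source may bear on it.

Measured in an ADME assay on BHK cells (Mesocricetus auratus) for cytotoxicity, read by MTT assay, with a stated time of 96 h; on this read-out higher numbers stand for lower toxicity in this test and lower numbers for higher toxicity in this test:
Compound 1 `O=C(NC(=S)Nc1cccc(C(F)(F)F)c1)c1ccccc1`: > 100000 nM (a limit)
Compound 2 `CC(=O)NC(=S)Nc1cccc(C(F)(F)F)c1`: > 100000 nM (a limit)

Among the compounds with values here, compound 2 offers no number, only a limit of the assay, and the one other value shown is a limit too: the limit of > 100000 nM in this assay, at which 2 of the 2 values shown sit. The next compound is compound 3 `FC(F)(F)c1cccc(NC(=S)Nc2ccccc2Br)c1`, with 2-bromophenyl in place of acetyl on an amide-type nitrogen. Within the data shown here, the only measured step bearing on this change is a step that the two limits leave unreadable from compound 1 to compound 2, and it has no readable size. It replaced one group on a carbonyl carbon, whereas here the whole acetyl leaves. The data therefore set no size for this change. Compound 3 may well stay at the limit, and any readable move could only be toward lower numbers. The expected move is an at least 1.4-fold lower number from compound 2 to compound 3 (0.15 log units; that floor lies within the scatter). For compound 3 the estimated value is 70000 nM, with an expected range from 20000 nM to 100000 nM.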

Compound 3, half-maximal cytotoxic concentration: 59000 nM
For compound 3 the middle estimate is 1.2-fold (0.07 log units) above the measured one; the range from low to high includes it.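

In this assay, within the data shown here, compound 3 gives 59000 nM, the first value in this set that is a number and not a limit. Putting 2-bromophenyl in place of acetyl on the amide-type nitrogen gives an at least 1.6-fold lower number from compound 2 to compound 3 (0.22 log units; that floor lies within the scatter), and this floor is all that can be read of the size of the change. The result shows that a change on this nitrogen can bring the read-out off the limit, which the two earlier compounds did not show: the limit of > 100000 nM in this assay, at which 2 of the 3 values shown sit.

Going by these compounds, it remains open whether the bromine contributes to this shift, as a plain phenyl on the same nitrogen would be needed to separate it from the ring. On these data alone, how an amine, a carboxylic acid or a longer alkyl chain at this place would read in this assay also remains open.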